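This account rests on a few compounds, and the source may have more. Where it says the series, first, only, none or still open, it means among the compounds named here.

For the measured compounds named here, in a functional assay on MCF7 cells (Homo sapiens) for inhibition, read by trypan blue exclusion, with a stated time of 3 days (on this read-out lower numbers stand for stronger inhibition and higher numbers for weaker inhibition), compound 3 (`COc1cc(C(=O)c2cn(-c3cccc(F)c3)cc2-c2ccccc2)cc(OC)c1OC`) stands highest of the three numbers so far at 350 nM against compound 2 (`COc1cc(C(=O)c2cn(-c3cccc(C)c3)cc2-c2ccccc2)cc(OC)c1OC`) at 120 nM and compound 1 (`COc1cc(C(=O)c2cn(-c3ccccc3)cc2-c2cccc(F)c2)cc(OC)c1OC`) at 57 nM on the same read-out. The change to compound 4 (`COc1cc(C(=O)c2cn(-c3ccc(F)cc3)cc2-c2ccccc2)cc(OC)c1OC`) is 4-fluorophenyl in place of 3-fluorophenyl on an aromatic nitrogen. Going by the values given here, the one measured step at this group (a 2.9-fold higher number from compound 2 to compound 3 (0.46 log units; beyond the scatter)) is modest and puts fluoro in place of methyl without moving the fluoro, so it gives no size for this change, and no step beyond the scatter is expected in this assay on that basis. The estimated step is small (a 1.2-fold lower number from compound 3 to compound 4 (0.07 log units; within the scatter)). For compound 4 the estimate is 300 nM (expected range 100 nM to 900 nM).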

Compound 4, half-maximal inhibitory concentration: 15 nM
Compound 4: the middle estimate sits 20-fold (1.30 log units) above what was measured; the whole stated range lies above it.
By their numbers in this assay, from the lowest: compound 4; then compound 1; then compound 2; then compound 3.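

In this assay, the position of the fluoro on the aryl group at the aromatic nitrogen matters, not just its presence: with the same atoms, 4-fluorophenyl in place of 3-fluorophenyl gives a large step (a 23-fold lower number from compound 3 to compound 4 (1.37 log units; beyond the scatter)). The 4-fluorophenyl group also improves on 3-methylphenyl (an 8.0-fold lower number from compound 2 to compound 4 (0.90 log units; beyond the scatter)), so the substituent's identity alone does not set the number at this nitrogen. Nothing available bears on the cause of these steps. On these data alone, whether a 4-methylphenyl, 4-methoxyphenyl or 4-aminophenyl group at this nitrogen would follow 4-fluorophenyl remains open.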